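This account rests on a few compounds, and the source may have more. Where it says the series, first, only, none or still open, it means among the compounds named here.

Two compounds of this series carry the same core and differ only in the group on a nitrogen on an aromatic ring. Compound 1, `N#Cc1cnc(NCc2cnccc2C(F)(F)F)cc1NC[C@H]1C[C@H](O)C1`, gives 700 nM in an assay on isolated protein for inhibition of protein kinase C theta type (Homo sapiens), read by TR-FRET, with a stated time of 2 h; a higher number here means a weaker inhibitor, a lower number a stronger inhibitor. Compound 2, `CC1(C)C[C@H](Nc2cc(NCc3cnccc3C(F)(F)F)ncc2C#N)CC[C@@H]1O`, gives 7 nM in the same assay, which is the lowest of the two numbers shown; the step of a 100-fold lower number from compound 1 to compound 2 (2.00 log units; beyond the scatter) separates it from compound 1.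

The next compound, compound 3, is `CC1(C)[C@@H](Nc2cc(NCc3cnccc3C(F)(F)F)ncc2C#N)C[C@@H]1C(N)=O`. It is reached from compound 2 by 3-carbamoyl-2,2-dimethylcyclobutyl in place of 4-hydroxy-3,3-dimethylcyclohexyl on a nitrogen on an aromatic ring. Going by the values given here, no measured pair reports this exact exchange. Among the compounds with values here, the only step that bears on it is a 100-fold lower number from compound 1 to compound 2 (2.00 log units; beyond the scatter), which shows that the group on this nitrogen matters greatly and that the four-membered ring of compound 1 sat at the weak end. Compound 3 returns to a four-membered ring, though now attached directly and bearing a carboxamide, so a modest loss against compound 2 is expected, with a step of a 4.3-fold higher number from compound 2 to compound 3 (0.63 log units; beyond the scatter). Compound 3 is therefore estimated at 30 nM, within 7 nM to 150 nM.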

Compound 3, half-maximal inhibitory concentration: 1100 nM
For compound 3 the middle estimate is 37-fold (1.56 log units) below the measured one, outside the stated range (above it).
By their numbers in this assay, from the lowest: compound 2; then compounds 1 and 3 (each within the scatter of the next).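

In this assay, replacing 4-hydroxy-3,3-dimethylcyclohexyl with 3-carbamoyl-2,2-dimethylcyclobutyl on the nitrogen gives a 160-fold higher number from compound 2 to compound 3 (2.20 log units; beyond the scatter), even though the two groups have the same count of heavy atoms and both carry dimethyl substitution. Compound 3 also stands level with compound 1, with a 1.6-fold higher number from compound 1 to compound 3 (0.20 log units; within the scatter), so attaching the four-membered ring directly to the nitrogen, adding dimethyl substitution and exchanging the hydroxyl for a carboxamide together leave the number where the (3-hydroxycyclobutyl)methyl group had it. Among these three compounds, only the six-membered ring of compound 2 gives a low number, and neither compound goes against that reading, but no measurement shown here explains it.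

Ring size and the exchange of hydroxyl for carboxamide change together from compound 2 to compound 3, so the compounds shown do not separate what each contributes. Still open, from the compounds shown here alone, is how the 3,3-dimethylcyclohexyl ring would read with a carboxamide or an amine in place of its hydroxyl, and how the directly attached 2,2-dimethylcyclobutyl ring would read with a hydroxyl in place of its carboxamide.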